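The source may report more compounds than this note shows. Statements on the series, on what has been measured and on what is new or still open speak of the compounds shown alone.

Compound 1 `Cc1ccc(-c2noc(CCCCCCC(=O)NO)n2)cc1` is one of two compounds tested in an assay on isolated protein for inhibition of histone deacetylase 8 (Homo sapiens), read by fluorescence, with a stated time of 10 min; a lower number here means a stronger inhibitor, a higher number a weaker inhibitor. In this assay compound 1 gives 5390 nM, the highest of the two numbers shown. For the measured compounds named here, the other measured compound, compound 2 `O=C(CCCCCCc1nc(-c2cccc([N+](=O)[O-])c2)no1)NO`, gives 2380 nM in this assay; the two compounds differ in more than one place, so their values can only be set side by side, and compound 2 is the one with the lower number, a gap that lies beyond the usual scatter. Compound 3 `O=C(CCCCCCc1nc(-c2cccnc2)no1)NO` is not yet measured. It differs from compound 1 by pyridin-3-yl in place of 4-methylphenyl on an aromatic carbon. Going by the values given here, no single-change step between measured compounds is known, so the size of this change has no direct precedent here. The step from compound 1 to compound 3 in this assay is expected to be a 1.3-fold lower number from compound 1 to compound 3 (0.13 log units; within the scatter), a change not beyond the scatter, with a slight lean toward a lower number. For compound 3 the estimated value in this assay is 4000 nM, with a range from 1500 nM to 11000 nM.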

Compound 3, half-maximal inhibitory concentration: 1830 nM
Beside the measured number, compound 3's estimate is 2.2-fold (0.34 log units) above it; low and high end bracket the measured number.
By their numbers in this assay, from the lowest: compounds 3 and 2 (each within the scatter of the next); then compound 1.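

In this assay, pyridin-3-yl in place of 4-methylphenyl gives a 2.9-fold lower number from compound 1 to compound 3 (0.47 log units; beyond the scatter), the first single-change step seen in this series. It shows that the group on this aromatic carbon, which lies between two ring nitrogen atoms of the five-membered ring, can shift the number beyond the scatter while the rest of compound 1 stays the same. No measurement here accounts for the size or direction of this step.

The step replaces the methyl-bearing carbocycle with a ring holding one nitrogen and one hydrogen-bond acceptor, so it cannot separate the effect of losing the methyl group from that of adding the ring nitrogen. The compounds shown leave open how an unsubstituted phenyl or a pyridin-4-yl group would read at this position, and whether the step would hold with a longer chain.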